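Replacing hydroxymethyl with cyano on a weakly characterised compound

The source may hold more compounds than are shown below. What is called first, only, known or untested is meant among the compounds shown, and "the series" means these compounds.

So far three compounds have been measured in a functional assay on the whole organism for inhibition, with Cavia porcellus as the target (on this read-out lower numbers stand for an effect already at smaller amounts and higher numbers for an effect only at larger amounts of compound), and only one of them has an exact number. Compound 1 (`Brc1cncc2nccn12`) gives 18 nM as a true measured value. Compound 2 (`OCc1cn2ccncc2n1`) gives > 200 nM as a limit and not as a number. Compound 3 (`NC(=O)c1cn2cc(Br)nc(Br)c2n1`) gives > 18 nM as a limit too. The position of compound 2 is therefore known only through that limit.

Compound 4 (`N#Cc1cn2ccncc2n1`) has not been measured yet. It keeps the shared core of compound 2 and carries cyano in place of hydroxymethyl on an aromatic carbon. For the measured compounds named here, no measured pair of compounds shows what this exchange does. The expected step that the limit leaves unreadable from compound 2 to compound 4 is estimated to stay within the usual scatter, with no clear direction. This expectation rests on compound 2 and its limit of > 200 nM as the only anchor. For compound 4 the expected value is 250 nM with an estimated range from 50 nM to 1200 nM in this test.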

Compound 4, concentration for half-maximal effect: > 167 nM
Compound 4 was reported as a limit (the forecaster's own chance of this, stated with the estimate: 45%); the middle value does not contradict the limit.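

In this assay compound 2 gives > 200 nM, which is a limit. For the compounds shown here, compound 4 gives > 167 nM, also a limit, and no step between compound 2 and compound 4 can be read. As far as these compounds go, whether cyano in place of hydroxymethyl on an aromatic carbon changes the effect, and in which direction, remains open.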